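This account rests on a few compounds, and the source may have more. Where it says the series, first, only, none or still open, it means among the compounds named here.

Measured so far:
compound 1 `COc1cc2nccc(Oc3ccc(NC(=O)c4nnc(-c5ccc(F)cc5)o4)cc3)c2cc1OC` — 52300 nM
compound 2 `COc1cc2c(Oc3ccc(NC(=O)c4cc(-c5ccc(F)cc5)on4)cc3)ccnc2cc1OCCCN1CCC(C)CC1` — 24600 nM

In a functional assay on HT-29 cells (Homo sapiens) for antiproliferative activity, read by MTT assay, with a stated time of 72 h (a lower number here means a stronger inhibitor, a higher number a weaker inhibitor), compound 1 gives 52300 nM and compound 2 gives 24600 nM. Compound 2 holds the lower of the two numbers; compound 1 lies above it by a margin beyond the scatter. The two differ in more than one place, so no single step can be read from them. Compound 3 `COc1cc2c(Oc3ccc(NC(=O)c4nnc(-c5ccc(F)cc5)o4)cc3)ccnc2cc1OCCCN1CCC(C)CC1` keeps the core of compound 2 and carries 5-(4-fluorophenyl)-1,3,4-oxadiazol-2-yl in place of 5-(4-fluorophenyl)-1,2-oxazol-3-yl on a carbonyl carbon. Among the measured compounds shown here, compound 1, the only compound here bearing the entering group, gives 52300 nM, so a small loss is expected, a 1.3-fold higher number from compound 2 to compound 3 (0.11 log units; within the scatter), probably within the scatter. Compound 3 is expected at 32000 nM, between 10000 nM and 100000 nM.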

Compound 3, half-maximal inhibitory concentration: 7890 nM
Beside the measured number, compound 3's estimate is 4.1-fold (0.61 log units) above it; measured number below the stated range.
By their numbers in this assay, from the lowest: compound 3; then compound 2; then compound 1.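

On a carbonyl carbon whose other neighbour is an amide-type nitrogen, 5-(4-fluorophenyl)-1,3,4-oxadiazol-2-yl in place of 5-(4-fluorophenyl)-1,2-oxazol-3-yl gives a 3.1-fold lower number from compound 2 to compound 3 (0.49 log units; beyond the scatter) in this assay, so this position responds to the swap between these two five-membered rings. Among the compounds shown here, with that oxadiazole group held constant, 2-(4-methylpiperidin-1-yl)ethyl in place of hydrogen gives a 6.6-fold lower number from compound 1 to compound 3 (0.82 log units; beyond the scatter) in this assay, the first single-place reading of this chain. No available measurement accounts for either step. Open, from the compounds shown here alone, is how a morpholine or a dimethylamine at the chain end would read, and whether a chlorine or a methoxy group in place of the fluorine on the phenyl ring would shift the number.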